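One added methoxy on a weakly active pair

This account rests on a few compounds, and the source may have more. Where it says the series, first, only, none or still open, it means among the compounds named here.

Measured in a functional assay on A549 cells (Homo sapiens) for inhibition, read by MTT assay, with a stated time of 72 h; a lower number here means a stronger inhibitor, a higher number a weaker inhibitor:
Compound 1 `COc1cc(/C=C/C(=O)c2c(OC)cc(O)c(CC=C(C)C)c2O)cc(OC)c1OC`: > 50000 nM, a limit of the assay
Compound 2 `COc1cc(/C=C/C(=O)c2c(O)cc(O)cc2OC)cc(OC)c1`: 34000 nM

Within the data shown here, compound 2 holds the only true number in this assay, at 34000 nM. Compound 1 reads > 50000 nM, which is a limit and not a number. Among the measured compounds shown here, no measured pair of compounds differs in a single place, so the size of a single change remains unseen.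

Compound 3 `COc1cc(/C=C/C(=O)c2c(O)cc(O)cc2OC)cc(OC)c1OC` differs from compound 2 by one change, methoxy in place of hydrogen on an aromatic carbon, ortho to two methoxy groups and para to a large group.

For the measured compounds named here, with no measured step as a guide, the step of a 1.4-fold lower number from compound 2 to compound 3 (0.13 log units; within the scatter) is expected to stay within the usual scatter, with no firm direction. Compound 3 is estimated at 25000 nM, with an expected range from 9000 nM to 60000 nM.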

Compound 3, half-maximal inhibitory concentration: 28400 nM
Beside the measured number, compound 3's estimate is 1.1-fold (0.06 log units) below it; measured number inside the range.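

In this assay, among these compounds, methoxy in place of hydrogen on an aromatic carbon, ortho to two methoxy groups and para to a large group, gives a 1.2-fold lower number from compound 2 to compound 3 (0.08 log units; within the scatter), so a first single change at this position leaves the two compounds reading alike. Hydrogen in place of 3-methylbut-2-en-1-yl on an aromatic carbon gives an at least 1.7-fold lower number from compound 1 to compound 3 (0.24 log units; that floor lies within the scatter), and this figure is only a floor, so the true size of the step stays unknown. That step rests on a limit of the assay, which is not a number, held by compound 1: the limit of > 50000 nM in this assay, at which 1 of the 3 values shown sits.

As far as these compounds go, it remains open whether an amine, a carboxylic acid or a longer chain in place of the methoxy at this position would move the number beyond the scatter. From the compounds shown here alone, it also remains open how large the step tied to 3-methylbut-2-en-1-yl really is.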